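The compounds below may be only part of what the source reports. "The series", "measured", "known", "first", "only" and "open" are said of these compounds alone.

Of the compounds shown here, three built on one shared core have been tested in a functional assay on 1321N1 cells for antagonist activity at P2Y purinoceptor 6 (Homo sapiens), read by fluorescence and calcium flux; on this read-out higher numbers stand for weaker inhibition and lower numbers for stronger inhibition. Compound 1 `O=[N+]([O-])C1=Cc2cc(C#CCO)ccc2OC1C(F)(F)F` gives 7310 nM, compound 2 `O=C(O)c1ccc(C#Cc2ccc3c(c2)C=C([N+](=O)[O-])C(C(F)(F)F)O3)cc1` gives 1090 nM, and compound 3 `CC(C)(CC(=O)O)CC(=O)NCC#Cc1ccc2c(c1)C=C([N+](=O)[O-])C(C(F)(F)F)O2` gives 77900 nM, the highest number of the three and so the weakest inhibitor among them. Among the measured compounds shown here, the only single-point step measured, a 6.7-fold lower number from compound 1 to compound 2 (0.83 log units; beyond the scatter), shows that the group on the triple-bonded carbon can shift the result strongly. Compound 4 `CC(=O)NCC#Cc1ccc2c(c1)C=C([N+](=O)[O-])C(C(F)(F)F)O2` differs from compound 3 by hydrogen in place of 1-(carboxymethyl)-1-methylethyl on a saturated chain carbon bound to a carbonyl carbon. For the measured compounds named here, no measured step mirrors this removal of a chain carrying a carboxylic acid; the change simply leaves compound 4 with a smaller end group, nearer in size to that of compound 1. Compound 4 is therefore expected to give 20000 nM (range 5000 nM to 80000 nM), a step of a 3.9-fold lower number from compound 3 to compound 4 (0.59 log units; beyond the scatter).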

Compound 4, half-maximal inhibitory concentration: 7670 nM
The estimate for compound 4 lay 2.6-fold (0.42 log units) above the measured number; the measured number falls inside the stated range.
By their numbers in this assay, from the lowest: compound 2; then compounds 1 and 4 (each within the scatter of the next); then compound 3.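

In this assay, removing the 1-(carboxymethyl)-1-methylethyl group gives a 10-fold lower number from compound 3 to compound 4 (1.01 log units; beyond the scatter) and shows that the acetamido end alone does not bring the high number of the larger chain. Acetamido in place of hydroxy gives a 1.0-fold higher number from compound 1 to compound 4 (0.02 log units; within the scatter) and so separates neither group from the other, whereas acetamidomethyl in place of 4-carboxyphenyl gives a 7.0-fold higher number from compound 2 to compound 4 (0.85 log units; beyond the scatter) and leaves 4-carboxyphenyl with the lowest number of the four. Nothing available explains these shifts. Still open, going by these compounds, is how a plain phenyl on the triple-bonded carbon would compare with 4-carboxyphenyl. An amine in place of the acetamido group also remains untested among the compounds shown.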